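The compounds below may be only part of what the source reports. "The series", "measured", "known", "first", "only" and "open" are said of these compounds alone.

Measured compounds:
Compound 1, `COc1ccc2c(c1OC)C(=O)N(Cc1cc(Br)ccc1NC(=O)c1ccccn1)C2=O`: > 100000 nM
Compound 2, `O=C(Nc1ccc(Cl)cc1CN1C(=O)c2ccccc2C1=O)c1ccco1`: 2300 nM

For the measured compounds named here, in an assay on CHO cells for positive allosteric modulation of metabotropic glutamate receptor 5 (Homo sapiens), read by FLIPR (a higher number here means that more compound is needed for the effect, a lower number that less compound is needed), compound 2 gives 2300 nM, and this is the only actual number in the set. Compound 1 sits at the limit of > 100000 nM in this assay, at which 1 of the 2 values shown sits, which is a limit of the assay rather than a measured number. Going by the values given here, compound 2 therefore stands alone as the one value from which to start.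

Compound 3, `COc1ccccc1C(=O)Nc1ccc(Cl)cc1CN1C(=O)c2ccccc2C1=O`, differs from compound 2 in a single place: 2-methoxyphenyl in place of furan-2-yl on a carbonyl carbon. Among the compounds with values here, no pair of measured compounds that differ in one place is available here, so the size of such a step has not been observed. Both groups are aromatic rings attached through the same amide carbonyl, and the rest of the molecule is kept unchanged. The step of a 1.5-fold lower number from compound 2 to compound 3 (0.19 log units; within the scatter) is expected to be small, lying within the usual scatter or only a little beyond it. Compound 3 is estimated at 1500 nM, with a range from 400 nM to 6000 nM.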

Compound 3, half-maximal effective concentration: > 100000 nM
Compound 3 ended at the assay's limit; the forecaster's own chance of this, stated with the estimate: 15%; middle value at least 66-fold (1.82 log units) away from the limit.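

Swapping furan-2-yl for 2-methoxyphenyl on a carbonyl carbon, with the rest of the molecule unchanged, is a large change in this assay, with an at least 43-fold higher number from compound 2 to compound 3 (1.63 log units; beyond the scatter), so this place is far less forgiving than a single value could suggest. From the compounds shown here alone, the value of compound 3, > 100000 nM, is a limit of the assay and not a number, so the real size of the step stays unknown. For the compounds shown here, this first readable step shows that two aromatic rings on the same amide carbonyl are not interchangeable here, and it leaves compound 2 as the only compound with an actual number: the limit of > 100000 nM in this assay, at which 2 of the 3 values shown sit.

One step cannot tell whether the loss follows from the change of ring itself or from the methoxy group that comes with it, and a plain phenyl or a thiophen-2-yl on the same carbonyl would help to separate the two. Going by these compounds, compound 1 differs from compound 2 in more than one place, so it says nothing about this change, and how far this place accepts anything other than furan-2-yl remains open.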